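Cytotoxicity notes on aryl-thiazole phenoxyacetamides

The compounds below may be only part of what the source reports. "The series", "measured", "known", "first", "only" and "open" are said of these compounds alone.

Measured compounds in a functional assay on A549 cells (Homo sapiens) for cytotoxicity, read by MTT assay, with a stated time of 48 h; on this read-out higher numbers stand for weaker inhibition and lower numbers for stronger inhibition:
compound 1, `Cc1ccc(-c2csc(NC(=O)COc3ccccc3)n2)cc1`, gives 41700 nM
compound 2, `Cc1ccc(-c2csc(NC(=O)COc3ccc(Br)cc3)n2)cc1`, gives 37200 nM
compound 3, `O=C(COc1ccc(Br)cc1)Nc1nc(-c2ccc(Br)cc2)cs1`, gives 46500 nM

All three measured compounds sit in a narrow band. From compound 2 to compound 1 the change is hydrogen in place of bromo on an aromatic carbon, and the step is a 1.1-fold higher number from compound 2 to compound 1 (0.05 log units; within the scatter). The two cores differ by bromo in place of methyl on an aromatic carbon, with the step of a 1.3-fold higher number from compound 2 to compound 3 (0.10 log units; within the scatter). Within the data shown here, compound 3 and compound 1 carry no computed step between them; their two values differ by a margin that the scatter covers.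

Compound 4, `O=C(COc1ccccc1)Nc1nc(-c2ccc(Br)cc2)cs1`, remains unmeasured. It differs from compound 3 by hydrogen in place of bromo on an aromatic carbon. Among the measured compounds shown here, this is the same change as the one from compound 2 to compound 1: the group that leaves, the group that enters and the place are described in identical words. That earlier step stayed within the scatter, and the cores of compound 2 and compound 3 give values that also sit within the scatter of each other, so the step from compound 3 to compound 4 is expected to be a 1.1-fold higher number from compound 3 to compound 4 (0.03 log units; within the scatter), essentially flat. The expectation rests on the step of a 1.1-fold higher number from compound 2 to compound 1 (0.05 log units; within the scatter) and on the value of compound 3, 46500 nM.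

Compound 4 is therefore estimated at 50000 nM in this assay, with a plausible range from 25000 nM to 100000 nM.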

Compound 4, half-maximal inhibitory concentration: 52900 nM
Compound 4: middle estimate off by 1.1-fold (0.02 log units), on the low side; low and high end bracket the measured number.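

In this assay, the change from 4-bromophenoxy to phenoxy gives a 1.1-fold higher number from compound 3 to compound 4 (0.06 log units; within the scatter), and this change reads the same on both cores: the same change on two cores in this assay, a 1.1-fold higher number (0.05 log units; within the scatter) from compound 2 to compound 1 and a 1.1-fold higher number (0.06 log units; within the scatter) from compound 3 to compound 4, 1.0-fold (0.01 log units) apart, within the scatter of two such steps. The change of bromo in place of methyl on an aromatic carbon gives a 1.3-fold higher number from compound 1 to compound 4 (0.10 log units; within the scatter), and it too reads the same on both cores: the same change on two cores in this assay, a 1.3-fold higher number (0.10 log units; within the scatter) from compound 2 to compound 3 and a 1.3-fold higher number (0.10 log units; within the scatter) from compound 1 to compound 4, 1.0-fold (0.01 log units) apart, within the scatter of two such steps. Across these four compounds, both changes can be carried from one core to the other without a visible difference, but every step involved lies within the scatter, so the agreement is between near-flat steps and does not show how a change with a step beyond the scatter would carry.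

The compounds shown hold only hydrogen, bromo and methyl at the two varied places, so it remains open whether any substituent there moves the number beyond the scatter. An amine or a carboxylic acid on either aromatic ring, or a longer chain in place of the linker of the phenoxyacetamide, would test whether this flat picture holds outside the narrow set of groups seen here.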